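The compounds below may be only part of what the source reports. "The series", "measured", "known", "first", "only" and "open" are said of these compounds alone.

For the measured compounds named here, in a functional assay on B16 cells (Mus musculus) for antiproliferative activity, read by MTT assay, with a stated time of 24 h (on this read-out lower numbers stand for stronger inhibition and higher numbers for weaker inhibition), compound 1 `COc1cc(OC)c(-c2coc3cc(OCc4ccccc4F)ccc3c2=O)cc1OC` gives 1610 nM and compound 2 `COc1cc(OC)c(-c2coc3cc(OCc4ccc(Cl)cc4)ccc3c2=O)cc1OC` gives 2400 nM as the only two numbers so far. These values lie within the usual scatter of each other, so compound 2 stands level with compound 1. Compound 3 `COc1cc(OC)c(-c2coc3cc(OCc4cccc(Cl)c4)ccc3c2=O)cc1OC` has not yet been measured. The change 3-chlorophenyl in place of 4-chlorophenyl on a saturated chain carbon bound to an oxygen on an aromatic ring puts 3-chlorophenyl in place of 4-chlorophenyl on a saturated chain carbon bound to an oxygen on an aromatic ring. Going by the values given here, one measured step bears on this: the step of a 1.5-fold higher number from compound 1 to compound 2 (0.17 log units; within the scatter) exchanged one substituted phenyl for another at that same place and stayed small. It does not test this exact change, however. In this assay no shift beyond the scatter is therefore expected, and no direction can be named. The estimated step of a 1.1-fold lower number from compound 2 to compound 3 (0.04 log units; within the scatter) is only a best guess. Compound 3 is expected at 2200 nM with a likely range from 800 nM to 5500 nM as its lower and upper ends.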

Compound 3, half-maximal inhibitory concentration: 2280 nM
Compound 3: middle estimate off by 1.0-fold (0.02 log units), on the low side; the measured number falls inside the stated range.
By their numbers in this assay, from the lowest: compounds 1, 3 and 2 (each within the scatter of the next).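

In this assay, for the compounds shown here, 3-chlorophenyl in place of 4-chlorophenyl gives a 1.1-fold lower number from compound 2 to compound 3 (0.02 log units; within the scatter) and so tests for the first time where the chlorine sits on the phenyl ring; across these two compounds, that placement shows no difference beyond the scatter. The exchange of 2-fluorophenyl for 3-chlorophenyl at the same place gives a 1.4-fold higher number from compound 1 to compound 3 (0.15 log units; within the scatter), so all three substituted phenyl groups shown now stand level in this assay and none can be ranked above another. Nothing measured here offers an explanation for these results.

The compounds shown carry only a single fluorine or chlorine on this phenyl ring, so they leave open how a ring bearing an amine or a carboxylic acid would read. They also leave open the effect of a longer chain between the oxygen and the ring.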